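The source may hold more compounds than are shown below. What is called first, only, known or untested is meant among the compounds shown, and "the series" means these compounds.

In a functional assay on HeLa cells (Homo sapiens) for antiproliferative activity, read by sulforhodamine B assay (a lower number here means a stronger inhibitor of growth, a higher number a weaker inhibitor of growth), compound 1 `CC[C@@H]1O[C@H](COCc2ccccc2)[C@@H](OCc2ccccc2)[C@H](OCc2ccccc2)[C@H]1O` gives 19800 nM and compound 2 `CCC[C@@H]1O[C@H](COCc2ccccc2)[C@@H](OCc2ccccc2)[C@H](OCc2ccccc2)[C@@H]1O` gives 23300 nM, two values within the usual scatter of each other. Compound 3 `CC(C)C[C@@H]1O[C@H](COCc2ccccc2)[C@@H](OCc2ccccc2)[C@H](OCc2ccccc2)[C@H]1O` gives > 50000 nM, which is a limit of the assay and not a number. Among the compounds with values here, it is the only compound at the limit of > 50000 nM in this assay, at which 1 of the 3 values shown sits.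

Compound 4 `CC(C)C[C@@H]1O[C@H](COCc2ccccc2)[C@@H](OCc2ccccc2)[C@H](OCc2ccccc2)[C@@H]1O` arises from compound 3 by a single change: the two compounds have the same atoms and bonds and differ only in configuration as drawn: 1 of 5 stereo elements differ; a stereocentre at a saturated ring carbon is drawn S in compound 3 and R in compound 4. At that ring carbon, compound 4 is drawn like compound 2, and compound 3 like compound 1.

Within the data shown here, the one measured step, an at least 2.5-fold higher number from compound 1 to compound 3 (0.40 log units; beyond the scatter), changes the side chain and keeps this configuration, so no measured step tests the configuration alone. The closest hint is that compound 1 and compound 2 differ at this carbon as well as in the chain, yet stay within the scatter of each other. A large change is therefore not expected, and any shift should be modest and towards a lower number. The estimated step is an at least 1.3-fold lower number from compound 3 to compound 4 (0.11 log units; that floor lies within the scatter). Compound 4 is expected at 38000 nM, with an estimated range from 18000 nM to 70000 nM.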

Compound 4, concentration for 50% growth inhibition: 24600 nM
Beside the measured number, compound 4's estimate is 1.5-fold (0.19 log units) above it; the range from low to high includes it.
By their numbers in this assay, from the lowest: compounds 1, 2 and 4 (each within the scatter of the next). At a limit, above all of these: compound 3.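

In this assay, the configuration at this ring carbon alone gives an at least 2.0-fold lower number from compound 3 to compound 4 (0.30 log units; that floor lies within the scatter). Within the data shown here, this is the first step to test that configuration without any change in the chain, and the true size of the step may be larger. Compound 3 is at a limit, so the step is only a floor: the limit of > 50000 nM in this assay, at which 1 of the 4 values shown sits.

With the ring carbon drawn R, methyl in place of hydrogen on the saturated chain carbon gives a 1.1-fold higher number from compound 2 to compound 4 (0.02 log units; within the scatter), so with this configuration the chain change leaves the number within the scatter.

On these data alone, whether the same configuration change would matter with the shorter chains of the other compounds stays open. Also open, as far as these compounds go, is how a longer chain, or a chain ending in an amine, would read in this assay with either configuration.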